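Fluoro for formyl on the pendant phenyl ring

A few compounds are considered here, and "the series" means these few. Any claim that something is new, unique, unknown or untested is made for them only; others in the source may bear on it.

Measured so far:
compound 1 `Brc1cn2ccnc2c(-c2ccc3ncn(C4CCCCC4)c3c2)n1` — 6.2%
compound 2 `c1ccc(-c2cn3ccnc3c(-c3ccc4ncn(C5CCCCC5)c4c3)n2)cc1` — 29.3%
compound 3 `O=Cc1ccc(-c2cn3ccnc3c(-c3ccc4ncn(C5CCCCC5)c4c3)n2)cc1` — 24.3%

In a functional assay on DU-145 cells (Homo sapiens) for inhibition, read by sulforhodamine B assay, with a stated time of 48 h, tested at 10 uM (on this read-out lower numbers stand for less inhibition and higher numbers for more inhibition at the one concentration tested (going by the name of the read-out)), compound 1 gives 6.2%, the lowest of the three numbers. Compound 3 stands second highest; its nearest neighbour is compound 2, and the two lie within the scatter of each other, while compound 1 is the furthest and sits beyond the scatter below compound 3.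

Compound 4 `Fc1ccc(-c2cn3ccnc3c(-c3ccc4ncn(C5CCCCC5)c4c3)n2)cc1` is not yet measured. The change from compound 3 is fluoro in place of formyl on an aromatic carbon.

The step that bears most directly on it is a number 5 percentage points lower from compound 2 to compound 3 (within the scatter), which shows that putting formyl onto that phenyl ring did not move the number beyond the scatter. The larger steps, a number 23.1 percentage points higher from compound 1 to compound 2 (beyond the scatter) and a number 18.1 percentage points higher from compound 1 to compound 3 (beyond the scatter), concern the phenyl in place of bromo, and compound 4 keeps the phenyl. Exchanging one small group for another on that ring is therefore expected to give no step beyond the scatter in this assay.

The estimate for compound 4 in this assay is 27%, within 14% to 40%, meaning an expected step of a number 2.7 percentage points higher from compound 3 to compound 4 (within the scatter).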

Compound 4, a percentage reported as inhibition, at one concentration (the size of the read-out at that concentration, not a potency): 1.17%
Compound 4: middle estimate off by 25.8 percentage points, on the high side, outside the stated range (below it).
By their numbers in this assay, from the lowest: compounds 4 and 1 (each within the scatter of the next); then compounds 3 and 2 (each within the scatter of the next).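

In this assay, the ring position para to a large group proves sensitive to what it carries: fluoro in place of formyl gives a number 23.1 percentage points lower from compound 3 to compound 4 (beyond the scatter), and fluoro in place of hydrogen gives a number 28.1 percentage points lower from compound 2 to compound 4 (beyond the scatter), whereas formyl in place of hydrogen had stayed within the scatter. A phenyl ring at this place of the core therefore does not by itself hold the number up: 4-fluorophenyl in place of bromo gives a number 5 percentage points lower from compound 1 to compound 4 (within the scatter), so it shows no gain over bromo, unlike phenyl and 4-formylphenyl. Nothing available here accounts for the drop that comes with fluoro.

The compounds shown leave open whether fluoro is a lone outlier at this position or part of a wider trend, which an amine, a methoxy or a carboxylic acid there would help to decide. They also leave open how these compounds behave at other concentrations.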